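A few compounds are considered here, and "the series" means these few. Any claim that something is new, unique, unknown or untested is made for them only; others in the source may bear on it.

Compound 1 `CCC1CCN(c2cc(C(F)(F)F)ccc2CNC(=O)C(C)c2ccc(NS(C)(=O)=O)c(F)c2)CC1`: 0.7 nM; compound 2 `CC(C(=O)NCc1ccc(C(F)(F)F)cc1N1CCC(c2ccc(F)cc2)CC1)c1ccc(NS(C)(=O)=O)c(F)c1`: 0.9 nM; compound 3 `Cc1cccc(N2CCN(c3cc(C(F)(F)F)ccc3CNC(=O)C(C)c3ccc(NS(C)(=O)=O)c(F)c3)CC2)c1`: 1.8 nM.

In an assay on CHO cells for antagonist activity at transient receptor potential cation channel subfamily V member 1 (Homo sapiens), read by FLIPR (a higher number here means a weaker inhibitor, a lower number a stronger inhibitor), compound 1 has the lowest number of the three; compound 2 lies within the scatter of it, while compound 3 sits beyond the scatter. Compound 4 `CCCCCCSc1cc(C(F)(F)F)ccc1CNC(=O)C(C)c1ccc(NS(C)(=O)=O)c(F)c1` differs from compound 1 in one place: hexylsulfanyl in place of 4-ethylpiperidin-1-yl on an aromatic carbon. Among the compounds with values here, the only single-point step available, a 1.3-fold higher number from compound 1 to compound 2 (0.11 log units; within the scatter), swaps the group on the saturated ring and says nothing about removing that ring for an open chain; no measured pair covers such a change. Compound 4 is therefore expected to give a somewhat higher number, a 7.1-fold higher number from compound 1 to compound 4 (0.85 log units; beyond the scatter), with wide uncertainty. The estimate for compound 4 is 5 nM, between 1 nM and 30 nM.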

Compound 4, inhibition constant: 1.8 nM
Beside the measured number, compound 4's estimate is 2.8-fold (0.44 log units) above it; low and high end bracket the measured number.
By their numbers in this assay, from the lowest: compounds 1, 2, 3 and 4 (each within the scatter of the next, the first and the last beyond it).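

In this assay, swapping the saturated ring at this aromatic carbon for an open chain, hexylsulfanyl in place of 4-ethylpiperidin-1-yl, gives a 2.6-fold higher number from compound 1 to compound 4 (0.41 log units; beyond the scatter) and so only a modest loss. A ring at this position is therefore not needed for a low number in this set. Nothing available explains the size of this step. On these data alone, what stays open is how much the sulfur and the chain length each contribute. A hexyloxy group, a hexylamino group or a shorter butylsulfanyl chain at this carbon would help separate the two.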